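A few compounds are considered here, and "the series" means these few. Any claim that something is new, unique, unknown or untested is made for them only; others in the source may bear on it.

Going by the values given here, in an in vivo ADME assay on the whole organism for pharmacokinetics, with Rattus norvegicus as the target (a higher number here means that more of the compound sits outside the plasma, a lower number that more of the compound stays in the plasma), compound 1 `O=C(Nc1cccnc1-c1ccsc1)N1CCN2C(=O)N([C@H]3C[C@@H]3c3ccccc3)C(=O)[C@@H]2C1` stands highest of the three compounds measured so far, at 10 L/kg. Compound 2 `CN(C)C(=O)c1cc(Cl)c(NC(=O)N2CCN3C(=O)N([C@H]4C[C@@H]4c4ccccc4)C(=O)[C@@H]3C2)c(Cl)c1` comes next with 2.1 L/kg, and compound 3 `CS(=O)(=O)c1cc(Cl)c(NC(=O)N2CCN3C(=O)N([C@H]4C[C@@H]4c4ccccc4)C(=O)[C@@H]3C2)c(Cl)c1` is lowest with 0.6 L/kg. All three share one core and differ only in the group on the amide-type nitrogen.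

The compound still to be measured is compound 4 `N#Cc1cc(Cl)c(NC(=O)N2CCN3C(=O)N([C@H]4C[C@@H]4c4ccccc4)C(=O)[C@@H]3C2)c(Cl)c1`, and the change from compound 1 is 2,6-dichloro-4-cyanophenyl in place of 2-(thiophen-3-yl)pyridin-3-yl on an amide-type nitrogen. Among the compounds with values here, no measured pair makes this exact swap. The closest evidence comes from compound 2 and compound 3, which carry the same dichlorinated phenyl ring as compound 4 and differ from it only in the remaining group, where compound 4 has its nitrile. Within the data shown here, the one measured step between them is a 3.5-fold lower number from compound 2 to compound 3 (0.54 log units; beyond the scatter), so that remaining group alone can move the number beyond the scatter.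

Compound 4 is therefore expected to land near compound 2 at 2.1 L/kg and compound 3 at 0.6 L/kg, far under compound 1 at 10 L/kg. The expected change is an 8.3-fold lower number from compound 1 to compound 4 (0.92 log units; beyond the scatter), a drop well beyond the scatter. For compound 4 the estimated value is 1.2 L/kg, with an expected range from 0.5 L/kg to 3 L/kg.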

Compound 4, volume of distribution at steady state: 0.5 L/kg
For compound 4 the middle estimate is 2.4-fold (0.38 log units) above the measured one, within the range that was stated.
By their numbers in this assay, from the lowest: compounds 4 and 3 (each within the scatter of the next); then compound 2; then compound 1.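

In this assay, putting 2,6-dichloro-4-cyanophenyl in place of 2-(thiophen-3-yl)pyridin-3-yl on the amide-type nitrogen gives a 20-fold lower number from compound 1 to compound 4 (1.30 log units; beyond the scatter) as a direct reading of this swap on the shared core, a large step for a single change of group. On the dichlorinated ring, the new compound also shows how much the remaining group matters: nitrile in place of methylsulfonyl gives a 1.2-fold lower number from compound 3 to compound 4 (0.08 log units; within the scatter) and so leaves the two groups indistinguishable here, whereas nitrile in place of dimethylcarbamoyl gives a 4.2-fold lower number from compound 2 to compound 4 (0.62 log units; beyond the scatter) as a clear step. Among these three groups on that ring, dimethylcarbamoyl therefore stands apart, while nitrile and methylsulfonyl share one level.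

The step from compound 1 to compound 4 replaces the whole group at once, so the compounds shown do not divide it among the two chlorines, the nitrile and the loss of the thiophene, and they do not show where an amine or a carboxylic acid on the dichlorinated ring would fall. No measurement shown here gives a reason for any of these differences.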